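The compounds below may be only part of what the source reports. "The series", "measured", "known", "first", "only" and "open" are said of these compounds alone.

Values in a functional assay on HOS cells (Homo sapiens) for inhibition, read by CCK-8 assay, with a stated time of 72 h, tested at 1 uM; on this read-out higher numbers stand for more inhibition at the one concentration tested (going by the name of the read-out) and lower numbers for less inhibition:
compound 1, `COc1ccc(C)cc1N1C(=O)CSC1c1cccc(C(=O)NCCCCc2ccccc2)c1`: 42%
compound 2, `COc1ccccc1N1C(=O)CSC1C(=O)NCCCCc1ccccc1`: 0%
compound 3, `O=C(NCCCCc1ccccc1)c1cccc(C2SCC(=O)N2c2ccccc2)c1`: 55%

Compound 3 stands highest of the three numbers, with compound 1 nearest and compound 2 furthest; both gaps lie beyond the scatter. Compound 4, `O=C(NCCCCc1ccccc1)c1cccc(C2SCC(=O)N2c2cccc(F)c2)c1`, differs from compound 3 by fluoro in place of hydrogen on an aromatic carbon. Among the measured compounds shown here, no measured step puts a single fluoro onto this ring; the only step touching that ring, a number 13 percentage points higher from compound 1 to compound 3 (beyond the scatter), exchanges a whole substitution pattern, so it bears on the question only loosely. A lone fluoro is expected to move this assay little, with no direction beyond the scatter. The expected step is a number 3 percentage points lower from compound 3 to compound 4 (within the scatter). Compound 4 is therefore estimated at 52%, within a range from 32% to 70%.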

Compound 4, a percentage reported as inhibition, at one concentration (the size of the read-out at that concentration, not a potency): 84%
Beside the measured number, compound 4's estimate is 32 percentage points below it; the measured number lies above the stated range.
By their numbers in this assay, from the lowest: compound 2; then compound 1; then compound 3; then compound 4.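

In this assay, the step of a number 29 percentage points higher from compound 3 to compound 4 (beyond the scatter) shows that this phenyl responds strongly to a single added fluoro, meta to a large group, with no other change to the molecule. The step of a number 42 percentage points higher from compound 1 to compound 4 (beyond the scatter) shows that, of the two substituted rings, 3-fluorophenyl gives the higher number, so substitution on this ring can raise the read-out as well as lower it. No available evidence bears on the reason for this rise.

As far as these compounds go, whether the gain is specific to fluoro or would also follow from another group at this place, such as chloro or nitrile, remains open. Also open, from the compounds shown here alone, is how fluoro at another place on this ring would read.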